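Adding 3-methoxyphenyl to the lactam nitrogen: a second look

A few compounds are considered here, and "the series" means these few. Any claim that something is new, unique, unknown or untested is made for them only; others in the source may bear on it.

Of the compounds shown here, three have been measured in a functional assay on MCF7 cells (Homo sapiens) for antiproliferative activity, read by MTT assay, with a stated time of 72 h; on this read-out higher numbers stand for weaker inhibition and lower numbers for stronger inhibition. Compound 1 `O=C1COc2ccc(-c3cccc(NS(=O)(=O)c4ccc(F)cc4)c3)cc2N1` gives 18300 nM in this assay. Compound 2 `COc1ncc(-c2ccc3c(c2)NC(=O)CO3)cc1NS(=O)(=O)c1ccc(F)cc1` gives 32300 nM in this assay; how its core differs from that of compound 1 is not broken down here, and the two values lie within the usual scatter of each other. For compound 3 `COc1cccc(N2C(=O)COc3ccc(-c4cnc(OC)c(NS(=O)(=O)c5ccc(F)cc5)c4)cc32)c1` this assay reports only a limit, > 40000 nM, which is the limit of > 40000 nM in this assay, at which 1 of the 3 values shown sits.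

Compound 3 is made from compound 2 by one change, (3-methoxyphenyl in place of hydrogen on an amide-type nitrogen in a ring). This change gave an at least 1.2-fold higher number from compound 2 to compound 3 (0.09 log units; that floor lies within the scatter).

Compound 4 `COc1cccc(N2C(=O)COc3ccc(-c4cccc(NS(=O)(=O)c5ccc(F)cc5)c4)cc32)c1` has not yet been measured in this assay. It is made from compound 1 by 3-methoxyphenyl in place of hydrogen on an amide-type nitrogen in a ring. The place of the change is described in the same words for both pairs, so this is the same change as that from compound 2 to compound 3, carried out on the core of compound 1 instead.

Because the measured instance of this change is an at least 1.2-fold higher number from compound 2 to compound 3 (0.09 log units; that floor lies within the scatter), the expectation is that compound 1 and compound 4 differ by about a 1.9-fold higher number from compound 1 to compound 4 (0.28 log units; within the scatter), a step expected to be of similar direction and at least similar size to the measured one, though a floor only is known there. On that basis compound 4 is estimated to give 35000 nM in this assay, with the estimate expected to fall between 18000 nM and 80000 nM. Given that compound 3 reached only the limit, there is a fair chance that compound 4 is also reported as a limit rather than a number.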

Compound 4, half-maximal inhibitory concentration: > 40000 nM
Compound 4: no number, only a limit; the forecaster's own chance of this, stated with the estimate: 40%; middle value at least 1.1-fold (0.05 log units) away from the limit.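

In this assay, compound 4 is reported only as a limit, > 40000 nM. Placing 3-methoxyphenyl on the amide-type nitrogen of the core of compound 1 gives an at least 2.1-fold higher number from compound 1 to compound 4 (0.33 log units; beyond the scatter), so on this core the change weakens inhibition by a margin that stands clear of the scatter, and on neither core does it bring a lower number: the same change on two cores in this assay, an at least 1.2-fold higher number (0.09 log units; that floor lies within the scatter) from compound 2 to compound 3 and an at least 2.1-fold higher number (0.33 log units; beyond the scatter) from compound 1 to compound 4; the limit leaves it open whether they differ. On these data alone, both compounds carrying 3-methoxyphenyl stop at the same limit, so the true size of the change on either core stays unknown, and the series shows only a shared direction, not that the change carries over with the same size from one core to the other: the limit of > 40000 nM in this assay, at which 2 of the 4 values shown sit.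

The compounds shown leave open whether the loss belongs to 3-methoxyphenyl in particular or to any group on this nitrogen, a question that a plain phenyl or a methyl group there would bear on. They also leave open whether a short chain ending in an amine or a carboxylic acid at the same nitrogen would give a measurable number on either core rather than a limit.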